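The compounds below may be only part of what the source reports. "The series", "measured", "known", "first", "only" and "open" are said of these compounds alone.

- Compound 1 `COc1ccc(NC(=O)CN2CCN(c3nnc(Cc4ccccc4)c4ccccc34)CC2)cc1OC`: 145000 nM
- Compound 2 `Cc1ccccc1NC(=O)CN1CCN(c2nnc(Cc3ccccc3)c3ccccc23)CC1`: 113000 nM
- Compound 3 `Cc1ccccc1NC(=O)CN1CCN(c2nnc(Cc3ccncc3)c3ccccc23)CC1`: 15000 nM

In a functional assay on HT-29 cells (Homo sapiens) for cytotoxicity, read by MTT assay, with a stated time of 72 h (on this read-out higher numbers stand for weaker inhibition and lower numbers for stronger inhibition), compound 2 gives 113000 nM, which places it in the upper pair of the three numbers. Compound 4 `O=C(CN1CCN(c2nnc(Cc3ccccc3)c3ccccc23)CC1)Nc1cccc(Br)c1` has 3-bromophenyl in place of 2-methylphenyl on an amide-type nitrogen. Among the compounds with values here, the closest precedent is a change at that same place, a 1.3-fold lower number from compound 1 to compound 2 (0.11 log units; within the scatter). The other measured step, a 7.5-fold lower number from compound 2 to compound 3 (0.88 log units; beyond the scatter), was larger but involved a different place, so it bears little on this change. A single precedent is thin evidence, but no step beyond the scatter is expected in this assay. The expected change is a 1.4-fold lower number from compound 2 to compound 4 (0.15 log units; within the scatter). For compound 4 the estimated value is 80000 nM, with an expected range of 25000 nM to 200000 nM.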

Compound 4, half-maximal inhibitory concentration: 13400 nM
The estimate for compound 4 lay 6.0-fold (0.78 log units) above the measured number, outside the stated range (below it).
By their numbers in this assay, from the lowest: compounds 4 and 3 (each within the scatter of the next); then compounds 2 and 1 (each within the scatter of the next).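

In this assay, an 8.4-fold lower number from compound 2 to compound 4 (0.93 log units; beyond the scatter) and an 11-fold lower number from compound 1 to compound 4 (1.03 log units; beyond the scatter) show that the aryl group on the amide-type nitrogen can matter, although the earlier change at this place stayed within the scatter. The identity of this group therefore affects the read-out, at least for 3-bromophenyl. No available evidence accounts for this difference.

The compounds shown leave open whether the bromine itself or its place on the phenyl ring carries the step, which 3-chlorophenyl, 3-methylphenyl or 2-bromophenyl could help separate. Also open, from the compounds shown here alone, is how 3-bromophenyl behaves alongside pyridin-4-yl.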